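Cyclohexyl in place of 2,2,2-trifluoroethyl on the shared core

The source may report more compounds than this note shows. Statements on the series, on what has been measured and on what is new or still open speak of the compounds shown alone.

In a functional assay on SH-SY5Y cells (Homo sapiens) for antagonist activity, read by cAMP accumulation (a higher number here means a more potent compound, by a factor of ten per unit of this negative logarithm, a lower number a less potent compound), compound 1 `CCCCOc1ccc(Cc2ccc(NC3=NCCN3)cc2)cc1` gives 9, compound 2 `CC(C)COc1ccc(Cc2ccc(NC3=NCCN3)cc2)cc1` gives 8.8 and compound 3 `FC(F)(F)COc1ccc(Cc2ccc(NC3=NCCN3)cc2)cc1` gives 8.7, which places compound 3 within the scatter of both others. Compound 4 `c1cc(NC2=NCCN2)ccc1Cc1ccc(OC2CCCCC2)cc1` is unmeasured and differs from compound 3 as follows: cyclohexyl in place of 2,2,2-trifluoroethyl on an oxygen on an aromatic ring. The bearing steps are a number 0.20 log units lower from compound 1 to compound 2 (within the scatter), a number 0.30 log units lower from compound 1 to compound 3 (within the scatter) and a number 0.10 log units lower from compound 2 to compound 3 (within the scatter), and all stay within the scatter. None of these measured groups has a ring, so the entering cyclohexyl is an extrapolation. No step beyond the scatter is expected in this assay. The estimated step is no change at the digits printed from compound 3 to compound 4 (within the scatter). The estimate for compound 4 is 8.7, with an expected range from 8.1 to 9.2.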

Compound 4, negative logarithm of the antagonist equilibrium constant: 8.6
Beside the measured number, compound 4's estimate is 0.10 log units above it, within the range that was stated.
By their numbers in this assay, from the lowest: compounds 4, 3, 2 and 1 (each within the scatter of the next, the first and the last beyond it).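

In this assay a six-membered carbon ring on the oxygen on an aromatic ring is accepted, with a number 0.10 log units lower from compound 3 to compound 4 (within the scatter) and a number 0.20 log units lower from compound 2 to compound 4 (within the scatter) as the steps from the two branched or fluorinated chains. Within the data shown here, only the comparison with butyl goes further: a number 0.40 log units lower from compound 1 to compound 4 (beyond the scatter) is modest, and it is the first step in these compounds to pass the scatter. Nothing available explains this step.

Open, going by these compounds, is whether phenyl or cyclopentyl on this oxygen would stay level with cyclohexyl. Also open, on these data alone, is how a longer chain such as hexyl, or a chain ending in an amine or a carboxylic acid, would compare with butyl.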